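The source may report more compounds than this note shows. Statements on the series, on what has been measured and on what is new or still open speak of the compounds shown alone.

Measured so far:
Compound 1 `COc1ccc(C2CC(c3cc4ccccc4o3)=NN2C(=O)c2ccncc2)c(O)c1`: > 190000 nM
Compound 2 `CCn1cc(C(=O)N2N=C(c3cc4ccccc4o3)CC2c2ccccc2O)c(=O)c2ccc(C)nc21`: > 157000 nM

In an ADME assay on Vero cells (Chlorocebus sabaeus) for cytotoxicity, read by MTT assay, with a stated time of 72 h (on this read-out lower numbers stand for stronger inhibition and higher numbers for weaker inhibition), compound 1 gives > 190000 nM, which is a limit of the assay and not a measured number. In this assay compound 2 gives > 157000 nM, again a limit rather than a number. For the measured compounds named here, compound 2 therefore stands at a limit, and the only other value shown is also a limit, so nothing here orders one compound against the other: the limit of > 157000 nM in this assay, at which 1 of the 2 values shown sits, and (the limit of > 190000 nM in this assay, at which 1 of the 2 values shown sits).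

Compound 3 `CCn1cc(C(=O)N2N=C(c3cc4ccccc4o3)CC2/C=C/c2ccccc2)c(=O)c2ccc(C)nc21` differs from compound 2 in one place: 2-phenylethenyl in place of 2-hydroxyphenyl on a saturated ring carbon. Going by the values given here, no measured step is available for a change of this kind, and with both known compounds at limits, no movement beyond the usual scatter is expected. Compound 3 is expected to show 180000 nM in this assay, estimated to lie between 50000 nM and 400000 nM. The estimated step that the limit leaves unreadable from compound 2 to compound 3 is expected to be essentially flat, most likely ending at another limit.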

Compound 3, half-maximal inhibitory concentration: > 168000 nM
Compound 3: no number, only a limit; the forecaster's own chance of this, stated with the estimate: 70%; the middle value does not contradict the limit.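

In this assay compound 3 gives > 168000 nM, which is a limit and not a number. Compound 2 also stands at a limit, so the step between compound 2 and compound 3 cannot be read. The compounds shown leave open whether replacing 2-hydroxyphenyl with 2-phenylethenyl changes cytotoxicity at all.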